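Swapping trifluoromethyl for chloro on the urea aryl ring

The compounds below may be only part of what the source reports. "The series", "measured", "known", "first", "only" and "open" are said of these compounds alone.

Measured compounds:
compound 1, `COc1cc2cc(Oc3ccc(NC(=O)Nc4cccc(C(F)(F)F)c4)cc3)c(C)nc2cc1OC`: 28200 nM
compound 2, `COc1cc2cc(Oc3ccc(NC(=O)Nc4ccc(Cl)c(C(F)(F)F)c4)cc3)c(C)nc2cc1OC`: 14400 nM

Both compounds were tested in a functional assay on SK-MEL-28 cells (Homo sapiens) for inhibition, read by sulforhodamine B assay, with a stated time of 48 h; a higher number here means that more compound is tolerated, a lower number that less compound is tolerated. Compound 1 and compound 2 cannot be told apart on these numbers, because a 2.0-fold lower number from compound 1 to compound 2 (0.29 log units; within the scatter) lies within the scatter; compound 2 is thus one of two values that sit close together, not a clear standout.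

The next compound, compound 3 `COc1cc2cc(Oc3ccc(NC(=O)Nc4ccc(Cl)c(Cl)c4)cc3)c(C)nc2cc1OC`, differs from compound 2 by chloro in place of trifluoromethyl on an aromatic carbon. Among the measured compounds shown here, no measured step touches this position: the single step known so far changes a different carbon of the same ring and was itself within the scatter, so it offers no direction. With nothing pointing either way, the step from compound 2 to compound 3 is expected to be small, a 1.1-fold higher number from compound 2 to compound 3 (0.05 log units; within the scatter), and to stay within the scatter. Compound 3 is therefore estimated at 16000 nM in this assay, with a range from 6000 nM to 40000 nM.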

Compound 3, concentration lethal to 50% of the cells: 51200 nM
Estimate against measurement, compound 3: 3.2-fold (0.51 log units) below; the measured number lies above the stated range.
By their numbers in this assay, from the lowest: compounds 2, 1 and 3 (each within the scatter of the next, the first and the last beyond it).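

In this assay, chloro in place of trifluoromethyl on this aromatic carbon gives a 3.6-fold higher number from compound 2 to compound 3 (0.55 log units; beyond the scatter), a modest step that, unlike the earlier step on a different carbon of the ring, lies beyond the scatter and shows that the number responds to the group at this position. The 3,4-dichlorophenyl group in place of 3-(trifluoromethyl)phenyl gives a 1.8-fold higher number from compound 1 to compound 3 (0.26 log units; within the scatter) and stays within the scatter, so that pair cannot be told apart on these numbers. No measurement on hand speaks to why the number responds to this change.

The compounds shown leave open where other groups at this carbon, such as a methoxy, a nitrile or an amine, would fall relative to compound 2 and compound 3. Also open, on these data alone, is whether the same swap gives a step of similar size when no chloro group stands on the ring.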